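From Compound 3 to Compound 4: An Oxirane Enters

This account rests on a few compounds, and the source may have more. Where it says the series, first, only, none or still open, it means among the compounds named here.

Measured in a functional assay on HepG2 cells (Homo sapiens) for cytotoxicity, read by MTT assay, with a stated time of 48 h; on this read-out higher numbers stand for weaker inhibition and lower numbers for stronger inhibition:
- Compound 1 `C=CC(C)(O)CC[C@@H]1C(=C)CC[C@H](Br)[C@@]1(C)CCC(O)C(C)(C)Cl`: 48700 nM
- Compound 2 `C=CC(C)(O)CC[C@@H]1C(=C)CC[C@H](Br)[C@@]1(C)CCC(O)C(C)(C)O`: > 100000 nM, a limit of the assay
- Compound 3 `C=CC(C)(O)CC[C@@H]1C(=C)CC[C@H](Br)[C@@]1(C)CCC(OC)C(C)(C)O`: > 100000 nM, a limit of the assay

Compound 3 has no exact number in this assay, only the limit > 100000 nM. It shares that position with one other compound, as the limit of > 100000 nM in this assay, at which 2 of the 3 values shown sit, records.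

Compound 4 `C=CC(C)(O)CC[C@@H]1C(=C)CC[C@H](Br)[C@@]1(C)CCC1OC1(C)C` has not yet been measured. It differs from compound 3 by 3,3-dimethyloxiran-2-yl in place of 2-hydroxy-1-methoxy-2-methylpropyl on a saturated chain carbon, two bonds along the chain from a saturated ring carbon, with 3,3-dimethyloxiran-2-yl in place of 2-hydroxy-1-methoxy-2-methylpropyl on a saturated chain carbon.

Only indirect evidence bears on this change. Among the compounds with values here, the two readable steps are an at least 2.0-fold higher number from compound 1 to compound 2 (0.31 log units; beyond the scatter) and an at least 2.0-fold higher number from compound 1 to compound 3 (0.31 log units; beyond the scatter), and both are lower bounds that start from compound 1, the only compound with a number. The step that the two limits leave unreadable from compound 2 to compound 3 adds nothing. Compound 1, at 48700 nM, suggests that this side chain position can bring a measurable value, so a modest move to a lower number is expected. The estimated change is an at least 1.4-fold lower number from compound 3 to compound 4 (0.15 log units; that floor lies within the scatter). For compound 4 the estimated value is 70000 nM, with an expected range from 25000 nM to 150000 nM.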

Compound 4, half-maximal inhibitory concentration: 53800 nM
Estimate against measurement, compound 4: 1.3-fold (0.11 log units) above; measured number inside the range.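

In this assay, the 3,3-dimethyloxiran-2-yl group gives compound 4 an exact number where the side chains of compound 2 and compound 3 gave none, and the steps read an at least 1.8-fold lower number from compound 3 to compound 4 (0.26 log units; that floor lies within the scatter) and an at least 1.8-fold lower number from compound 2 to compound 4 (0.26 log units; that floor lies within the scatter). A second side chain, besides the 2-chloro-1-hydroxy-2-methylpropyl group of compound 1, thus yields a measurable value, and the two cannot be told apart: a 1.1-fold higher number from compound 1 to compound 4 (0.04 log units; within the scatter). Compound 2 and compound 3 stay at a limit of the assay: the limit of > 100000 nM in this assay, at which 2 of the 4 values shown sit.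

As far as these compounds go, the true size of the steps from those two compounds stays open, as each gives only a floor. Also open, from the compounds shown here alone, is how an amine or a longer chain at this place would read, and whether the three-membered ring itself matters.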